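From 4-hydroxypiperidin-1-yl to 4-aminopiperidin-1-yl: half-life notes

The compounds below may be only part of what the source reports. "The series", "measured", "known", "first", "only" and "open" are said of these compounds alone.

Measured in an in vivo ADME assay on the whole organism (strain Sprague-Dawley) for metabolic stability, with Rattus norvegicus as the target, given by the intravenous route; on this read-out higher numbers stand for a longer-lived compound and lower numbers for a shorter-lived compound:
- compound 1 `O=C(C[C@H]1CC[C@]2(CC1)OO[C@]1(O2)C2CC3CC(C2)CC1C3)N1CCNCC1` (1.7 h)
- compound 2 `O=C(C[C@H]1CC[C@]2(CC1)OO[C@]1(O2)C2CC3CC(C2)CC1C3)N1CCC(O)CC1` (11 h)

Within the data shown here, compound 2 (11 h) is the higher of the two measured numbers, and compound 1 is its only neighbour. The next case is compound 3 `NC1CCN(C(=O)C[C@H]2CC[C@]3(CC2)OO[C@]2(O3)C3CC4CC(C3)CC2C4)CC1` with a single change (amino in place of hydroxy on a saturated ring carbon) that puts amino in place of hydroxy on a saturated ring carbon, in a six-membered non-aromatic ring with 1 nitrogen. Among the measured compounds shown here, only one measured step bears on this (a 6.5-fold higher number from compound 1 to compound 2 (0.81 log units; beyond the scatter)) and it lies beyond the scatter. It is not the same change, since it sets 4-hydroxypiperidin-1-yl in place of piperazin-1-yl on a carbonyl carbon. It does show that this assay responds to changes in the group on the carbonyl. Compound 3 keeps the ring of compound 2 but, like compound 1, carries a nitrogen in that group outside the amide. With a single step as a guide, this is a weak analogy. The expected move is downward (a 3.1-fold lower number from compound 2 to compound 3 (0.50 log units; beyond the scatter)) and smaller than that single step. Compound 3 is estimated at 3.5 h (range 1.5 h to 9 h).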

Compound 3, half-life: 1.38 h
Beside the measured number, compound 3's estimate is 2.5-fold (0.40 log units) above it; measured number outside the range, below it.
By their numbers in this assay, from the lowest: compounds 3 and 1 (each within the scatter of the next); then compound 2.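

In this assay, amino in place of hydroxy on the saturated ring carbon, with the rest of compound 2 unchanged, gives an 8.0-fold lower number from compound 2 to compound 3 (0.90 log units; beyond the scatter), so the long half-life depends on the group at this place, three ring bonds from the ring nitrogen, and not on the piperidine ring alone. The comparison with the first compound gives a 1.2-fold lower number from compound 1 to compound 3 (0.09 log units; within the scatter) and thus no separation between the 4-aminopiperidin-1-yl and piperazin-1-yl groups on the carbonyl carbon, which leaves compound 2 apart from the two nitrogen-bearing groups, with no compound among these three going against that grouping. No measurement here accounts for the drop on leaving hydroxy.

Open, as far as these compounds go, is where a methoxy group, an acetylated amine or a carboxylic acid on the same ring carbon would fall relative to hydroxy and amino in this assay. Also open, from the compounds shown here alone, is whether a plain piperidin-1-yl group, with nothing on that carbon, would stand with compound 2 or with compound 1 and compound 3.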